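The source may hold more compounds than are shown below. What is called first, only, known or untested is meant among the compounds shown, and "the series" means these compounds.

In an ADME assay (Rattus norvegicus) for activation, read by fluorescence, with a stated time of 60 min, tested at 1 ug/mL (a higher number here means that the compound crosses the layer faster, a lower number that the compound crosses the layer more slowly), the compounds tested so far stand as follows

Compound 1 `CCCCCCCCCCCCCCCCCCOC(=O)CN(C)C(=N)N` – "not determined" (no result reported)
Compound 2 `CCCCOC(=O)CN(C)C(=N)N` – 1.23 10^-6 cm/s
Compound 3 `CCCCCCCCCCCCOC(=O)CN(C)C(=N)N` – 0.7 10^-6 cm/s

Compound 3 (0.7 10^-6 cm/s) and compound 2 (1.23 10^-6 cm/s) lie within the usual scatter of repeated measurements of each other, and compound 1 has no number to set beside them. Going by the values given here, compound 3 therefore cannot be told apart from the only other compound with a number.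

Compound 4 `CCCCCCCCCOC(=O)CN(C)C(=N)N` has not yet been measured in this assay and differs from compound 3 by hydrogen in place of propyl on a saturated chain carbon, nine bonds along the chain from an oxygen next to a carbonyl group. Among the compounds with values here, no pair of measured compounds differs in one place only, so no direct precedent exists for this change. The closeness of the two available numbers suggests only a small move. The estimated step of a 1.3-fold higher number from compound 3 to compound 4 (0.11 log units; within the scatter) is expected to stay within the scatter, in no reliable direction. For compound 4 the estimate is 0.9 10^-6 cm/s with a range (0.45 10^-6 cm/s to 1.8 10^-6 cm/s) expected to hold most repeat measurements.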

Compound 4, apparent permeability in the Rattus norvegicus assay: 1.49 10^-6 cm/s
Estimate against measurement, compound 4: 1.7-fold (0.22 log units) below; the measured number falls inside the stated range.
By their numbers in the Rattus norvegicus assay, from the lowest: compounds 3, 2 and 4 (each within the scatter of the next, the first and the last beyond it).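

In the Rattus norvegicus assay, hydrogen in place of propyl on a saturated chain carbon, nine bonds along the chain from an oxygen next to a carbonyl group, gives a 2.1-fold higher number from compound 3 to compound 4 (0.33 log units; beyond the scatter), so a change at this place can move the number, though only modestly. In the Rattus norvegicus assay, pentyl in place of hydrogen on a saturated chain carbon, four bonds along the chain from an oxygen next to a carbonyl group, gives a 1.2-fold higher number from compound 2 to compound 4 (0.08 log units; within the scatter), so this second change cannot be told from repeat-to-repeat variation. In a physicochemical assay for lipophilicity (on this read-out higher numbers stand for higher lipophilicity and lower numbers for lower lipophilicity), compound 3 gives 3.81 and compound 4 gives 2.47 on this read-out. In the physicochemical assay, the change that separates compound 3 from compound 4 is large: the measured partition coefficient of compound 3, 3.81, and of compound 4, 2.47, a number 1.34 log units lower (beyond the scatter)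

Still open, on these data alone, is how the number in the Rattus norvegicus assay would respond to an amine or a carboxylic acid on a saturated chain carbon. Equally open, as far as these compounds go, is what a branched chain would do at this place.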